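The source may report more compounds than this note shows. Statements on the series, on what has been measured and on what is new or still open speak of the compounds shown alone.

Measured compounds in this set:
- compound 1 `O=c1[nH]c(C2CCc3ccccc3O2)nc2ccc(-c3cn[nH]c3)cc12`: 2 nM
- compound 2 `COc1cccc2c1OCC(c1nc3ccc(-c4cn[nH]c4)cc3c(=O)[nH]1)C2`: 423 nM
- compound 3 `Cc1ccc2c(c1)CC(c1nc3ccc(-c4cn[nH]c4)cc3c(=O)[nH]1)CO2`: 6 nM

All three share one core and were run in an assay on isolated protein for inhibition of Rho-associated protein kinase 2 (Homo sapiens), read by HTRF; a lower number here means a stronger inhibitor, a higher number a weaker inhibitor. Compound 1 gives 2 nM, compound 2 gives 423 nM, and compound 3 gives 6 nM. On these numbers compound 3 stands second highest of the three: its nearest neighbour is compound 1, whose lower number lies beyond the usual scatter, and its furthest is compound 2, whose higher number lies far beyond it. Within the data shown here, no single-change pairs exist among the measured compounds, so no measured step can be drawn on directly.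

Compound 4 `O=C(NC1CC1)c1ccc2c(c1)CC(c1nc3ccc(-c4cn[nH]c4)cc3c(=O)[nH]1)CO2` has not yet been run in this assay. It differs from compound 3 by cyclopropylcarbamoyl in place of methyl on an aromatic carbon. The methyl that leaves sits at the same place, so the comparison is a clean one; nothing in the set shows what a carbamoyl at that place does.

Among the measured compounds shown here, with no guiding step, the expectation is a small move toward a higher number, quite possibly within the scatter, as a 2.5-fold higher number from compound 3 to compound 4 (0.40 log units; beyond the scatter). Compound 4 is therefore estimated at 15 nM, with a range from 3 nM to 80 nM.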

Compound 4, half-maximal inhibitory concentration: 1 nM
The estimate for compound 4 lay 15-fold (1.18 log units) above the measured number; the whole stated range lies above it.
By their numbers in this assay, from the lowest: compounds 4 and 1 (each within the scatter of the next); then compound 3; then compound 2.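

In this assay, cyclopropylcarbamoyl in place of methyl on this aromatic carbon gives a 6.0-fold lower number from compound 3 to compound 4 (0.78 log units; beyond the scatter), so the change lowers the number rather than raising it. Until now, this place had shown only a methyl; it now also accommodates a substituent of six heavy atoms, with a three-membered ring, a hydrogen-bond donor and a hydrogen-bond acceptor, and the larger group comes with a stronger inhibitor in this comparison. No measurement in hand explains the step, so it stands as an observation about this one pair.

As far as these compounds go, a single step cannot separate the contribution of the carbonyl and the amide hydrogen from that of the cyclopropyl ring, so it remains open whether a plain primary carboxamide, an N-methyl carboxamide, a carboxylic acid or an aminomethyl group at the same place would also give a low number. Also open, from the compounds shown here alone, is whether cyclopropylcarbamoyl would give a step of similar size on the core of compound 1, or whether this step belongs only to the core of compound 3.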